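Swapping a Ring Nitrogen for Sulfur: Solubility Outlook

A few compounds are considered here, and "the series" means these few. Any claim that something is new, unique, unknown or untested is made for them only; others in the source may bear on it.

Compound 2 `CC(C)C(/C=C1\NC(=O)NC1=O)c1ccc(-c2ccc3cccc(F)c3c2)[nH]c1=O` sits at the bottom of a small set of three. In a physicochemical assay for solubility, in phosphate buffer, measured as kinetic solubility (on this read-out lower numbers stand for lower solubility and higher numbers for higher solubility), compound 2 gives 10700 nM, while compound 1 `CC(C)[C@@H](C[C@H]1SC(=O)NC1=O)c1ccc(-c2ccc3cccc(F)c3c2)[nH]c1=O` gives 23900 nM and compound 3 `O=C1NC(=O)/C(=C/C(c2ccccc2)c2ccc(-c3ccc4cccc(F)c4c3)[nH]c2=O)O1` gives 32800 nM; both of these gaps lie beyond the usual scatter. Compound 4 `CC(C)C(/C=C1\SC(=O)NC1=O)c1ccc(-c2ccc3cccc(F)c3c2)[nH]c1=O` is the next step from compound 2: a group of 8 heavy atoms (4 carbon, 1 nitrogen, 2 oxygen, 1 sulfur; one five-membered non-aromatic ring with 2 hetero atoms) in place of a group of 8 heavy atoms (4 carbon, 2 nitrogen, 2 oxygen; one five-membered non-aromatic ring with 2 hetero atoms), on a saturated chain carbon bound to an aromatic carbon and a saturated chain carbon. Among the compounds with values here, no two measured compounds differ in only this one place, so the size of this step has to be judged from the whole set. A modest rise is expected, estimated as a 1.7-fold higher number from compound 2 to compound 4 (0.23 log units; within the scatter). Compound 4 is expected to reach about 18000 nM, within a range of 8000 nM to 40000 nM, because compound 1 with its sulfur-bearing ring gives 23900 nM.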

Compound 4, solubility: 25600 nM
Compound 4: the middle estimate sits 1.4-fold (0.15 log units) below what was measured; measured number inside the range.
By their numbers in this assay, from the lowest: compound 2; then compounds 1, 4 and 3 (each within the scatter of the next).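

Within the data shown here, this is the first pair in the set that differs in one place only, so the exchange of a ring nitrogen for sulfur on this saturated chain carbon can now be read directly: it gives a 2.4-fold higher number from compound 2 to compound 4 (0.38 log units; beyond the scatter) in this assay and lies beyond the scatter. At this position, then, that single ring atom is enough to shift the read-out. Nothing measured here explains the rise.

Still open, going by these compounds, is how a carboxylic acid or an amine would compare in this place, and whether the same exchange gives a similar step on the saturated chain of compound 1.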